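A few compounds are considered here, and "the series" means these few. Any claim that something is new, unique, unknown or untested is made for them only; others in the source may bear on it.

Compound 1 `CCSc1ccc([C@H](c2cc3cc(Br)ccc3nc2OC)[C@@](O)(CCN(C)C)c2cccc(F)c2)cn1` stands highest of the three compounds measured in an ADME assay on microsomes from liver (Homo sapiens) for metabolic stability (on this read-out higher numbers stand for a longer-lived compound and lower numbers for a shorter-lived compound), where compound 1 gives 1.07 h. Compound 3 `COc1nc2ccc(Br)cc2cc1[C@@H](c1cc(C)c(C)s1)[C@@](O)(CCN(C)C)c1cccc(F)c1` gives 1 h in this assay, a step of a 1.1-fold lower number from compound 1 to compound 3 (0.03 log units; within the scatter). Compound 2 `COc1nc2ccc(Br)cc2cc1[C@@H](c1cncc(C)c1)[C@@](O)(CCN(C)C)c1cccc(F)c1` gives 0.2 h in this assay. Compound 4 `COc1cc([C@H](c2cc3cc(Br)ccc3nc2OC)[C@@](O)(CCN(C)C)c2cccc(F)c2)cnc1OC` is not yet measured in this assay; its change from compound 1 is 5,6-dimethoxypyridin-3-yl in place of 6-(ethylsulfanyl)pyridin-3-yl on a saturated chain carbon bound to an aromatic carbon and a saturated chain carbon. The step from compound 1 to compound 2, also an exchange of one pyridin-3-yl for another at the same saturated chain carbon, bears most on it: a 5.4-fold lower number from compound 1 to compound 2 (0.73 log units; beyond the scatter). The step from compound 1 to compound 3 was within the scatter. A lower number is therefore expected for compound 4, a 2.7-fold lower number from compound 1 to compound 4 (0.43 log units; beyond the scatter), with a drop smaller than that to compound 2 also possible. Compound 4 is estimated at 0.4 h in this assay, between 0.15 h and 1 h.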

Compound 4, half-life: 0.317 h
Beside the measured number, compound 4's estimate is 1.3-fold (0.10 log units) above it; measured number inside the range.
By their numbers in this assay, from the lowest: compounds 2 and 4 (each within the scatter of the next); then compounds 3 and 1 (each within the scatter of the next).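

In this assay a second oxygen-bearing substitution pattern on pyridin-3-yl, 5,6-dimethoxypyridin-3-yl, does not hold the number of 6-(ethylsulfanyl)pyridin-3-yl (a 3.4-fold lower number from compound 1 to compound 4 (0.53 log units; beyond the scatter)) or of 4,5-dimethylthiophen-2-yl (a 3.2-fold lower number from compound 3 to compound 4 (0.50 log units; beyond the scatter)). It is not separated from 5-methylpyridin-3-yl (a 1.6-fold higher number from compound 2 to compound 4 (0.20 log units; within the scatter)), so two differently substituted pyridin-3-yl groups now sit together, with compound 1 the pyridin-3-yl that goes against them. Nothing given here accounts for these differences. Open, as far as these compounds go, is whether the sulfur or the ethyl chain of compound 1 carries its number. An amine or a longer chain on the pyridin-3-yl would test how far this position tolerates change.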